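Trading Chloro for Methoxy on a Shared Core

The compounds below may be only part of what the source reports. "The series", "measured", "known", "first", "only" and "open" are said of these compounds alone.

In a functional assay on B16 cells (Mus musculus) for inhibition (a lower number here means a stronger inhibitor, a higher number a weaker inhibitor), compound 1 `CC(C)=CC(=O)OCc1cc(=O)oc2ccc(Cl)cc12` gives > 10 ug/mL, which is a limit of the assay and not a number. Compound 2 `COc1ccc2c(COC(=O)C=C(C)C)cc(=O)oc2c1`, which carries a methoxy group on a similar framework, gives > 10 ug/mL, and this too is a limit. Among the measured compounds shown here, the whole picture so far is the limit of > 10 ug/mL in this assay, at which 2 of the 2 values shown sit, so neither compound has yet given a true number, and no measured step is available as a guide.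

Compound 3 `COc1ccc2oc(=O)cc(COC(=O)C=C(C)C)c2c1` is reached from compound 1 by a single change: methoxy in place of chloro on an aromatic carbon. In words, this is methoxy in place of chloro on an aromatic carbon, and the rest of the molecule stays the same.

The expectation for this change in this assay is no shift beyond the usual scatter, and it rests on compound 2, a methoxy compound that reads > 10 ug/mL. The estimated step that the limit leaves unreadable from compound 1 to compound 3 is therefore small and has no firm direction. A reading at the same limit is the likeliest outcome. If a number does appear, the expected value for compound 3 is 14 ug/mL, within an estimated range of 6 ug/mL to 40 ug/mL.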

Compound 3, half-maximal inhibitory concentration: > 10 ug/mL
Compound 3 gave a limit, no number; the forecaster's own chance of this, stated with the estimate: 75%; the middle value is on the limit's open side.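

No step can be read from compound 1 to compound 3, because both compounds give a limit of the assay and not a number: the limit of > 10 ug/mL in this assay, at which 3 of the 3 values shown sit.

The compounds shown leave open whether methoxy in place of chloro on an aromatic carbon changes inhibition at all, and how strongly, if at all, any of these three compounds inhibits.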